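Aryl swaps on the sulfonyl sulfur of a shared core

The source may report more compounds than this note shows. Statements on the series, on what has been measured and on what is new or still open speak of the compounds shown alone.

Measured so far, in an assay on isolated protein for displacement of a labelled ligand from metabotropic glutamate receptor 5 (Homo sapiens), with a stated time of 60 min, tested at 1 uM; a lower number here means less inhibition, a higher number more inhibition at the concentration tested (going by the name of the read-out):
compound 1 `COc1ccc2ncc(S(=O)(=O)c3cc(F)cc(F)c3)c(N3CCC(C)CC3)c2c1` — 30%
compound 2 `COc1ccc2ncc(S(=O)(=O)c3ccc(OC)c(Cl)c3)c(N3CCC(C)CC3)c2c1` — 21%

Compound 2 holds the lowest of the two numbers in this assay; its nearest neighbour is compound 1, and the two sit within the scatter of each other, so no order between them can be read. Compound 3 `COc1cccc(S(=O)(=O)c2cnc3ccc(OC)cc3c2N2CCC(C)CC2)c1` is not yet measured. It differs from compound 2 in one place: 3-methoxyphenyl in place of 3-chloro-4-methoxyphenyl on a sulfonyl sulfur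

Among the measured compounds shown here, the only measured step that bears on this change is the one on the same sulfonyl sulfur, a number 9 percentage points lower from compound 1 to compound 2 (within the scatter), which exchanged one aryl group for another and stayed within the scatter. With a single aryl swap on that sulfur leaving the number essentially unchanged, a further aryl swap is expected to give no step beyond the scatter either; the estimated step is a number 1 percentage points higher from compound 2 to compound 3 (within the scatter). Compound 3 is therefore estimated at 22%, with a range from 8% to 38%.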

Compound 3, a percentage reported as inhibition, at one concentration (the size of the read-out at that concentration, not a potency): 0%
Compound 3: the middle estimate sits 22 percentage points above what was measured, and the stated range ends above it.
By their numbers in this assay, from the lowest: compound 3; then compounds 2 and 1 (each within the scatter of the next).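

In this assay, the aryl group on the sulfonyl sulfur now gives steps beyond the scatter: a number 21 percentage points lower from compound 2 to compound 3 (beyond the scatter) with 3-methoxyphenyl in place of 3-chloro-4-methoxyphenyl, and a number 30 percentage points lower from compound 1 to compound 3 (beyond the scatter) with 3-methoxyphenyl in place of 3,5-difluorophenyl. The earlier pair allowed no order to be read, whereas 3-methoxyphenyl stands apart from both other aryl groups, so the number at this position does depend on which aryl group the sulfur carries. Nothing measured here accounts for this difference.

Still open, on these data alone, is whether the low number is particular to 3-methoxyphenyl or would also appear with an unsubstituted phenyl or a benzyl group on the sulfur. Also open, as far as these compounds go, is whether the same gap would hold with another group on the shared core, such as a carboxylic acid or a longer alkyl chain.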